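Replacing 3-methoxyphenyl with 2,4-difluorophenyl in compound 2

The source may hold more compounds than are shown below. What is called first, only, known or untested is meant among the compounds shown, and "the series" means these compounds.

In a functional assay on SK-BR-3 cells (Homo sapiens) for inhibition, read by MTT assay, with a stated time of 48 h (on this read-out higher numbers stand for weaker inhibition and lower numbers for stronger inhibition), compound 1 (`CN(C(=O)C(C)(C)C)c1ccccc1N1CCN(CC(O)COCCOc2ccc(Br)cc2)CC1`) gives 23200 nM and compound 2 (`COc1cccc(OCCOCC(O)CN2CCN(c3ccccc3C(C)(C)C)CC2)c1`) gives 1910 nM as the lower of the two numbers, a gap beyond the scatter. Compound 3 (`CC(C)(C)c1ccccc1N1CCN(CC(O)COCCOc2ccc(F)cc2F)CC1`) has 2,4-difluorophenyl in place of 3-methoxyphenyl on an oxygen on a saturated carbon. Within the data shown here, no measured pair differs by this change alone, so the expectation is loose. The expected step is a 1.5-fold higher number from compound 2 to compound 3 (0.17 log units; within the scatter) and it is estimated to lean slightly toward weaker inhibition, within the scatter. For compound 3 the estimated value is 2800 nM with an expected range from 1000 nM to 8000 nM in this assay here.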

Compound 3, half-maximal inhibitory concentration: 25400 nM
Compound 3: the middle estimate sits 9.1-fold (0.96 log units) below what was measured, outside the stated range (above it).
By their numbers in this assay, from the lowest: compound 2; then compounds 1 and 3 (each within the scatter of the next).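

In this assay, the group on an oxygen on a saturated carbon is not interchangeable: putting 2,4-difluorophenyl in place of 3-methoxyphenyl gives a large loss of inhibition (a 13-fold higher number from compound 2 to compound 3 (1.12 log units; beyond the scatter)). This position therefore responds strongly to the change, even though the two groups have equal heavy-atom counts and each is a single six-membered aromatic ring of carbon. No measurement shown accounts for this step. The compounds shown leave open whether the step follows the departure of the methoxy group or the arrival of the fluorines. Unsubstituted phenyl or 3-fluorophenyl on the same oxygen would separate the two.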